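A few compounds are considered here, and "the series" means these few. Any claim that something is new, unique, unknown or untested is made for them only; others in the source may bear on it.

Measured in an ADME assay on HS27 cells (Homo sapiens) for antiproliferative activity, read by sulforhodamine B assay, with a stated time of 48 h; on this read-out higher numbers stand for weaker inhibition and lower numbers for stronger inhibition:
- Compound 1 `O=C(O)c1cc2cc(-c3ccc(F)cc3)ccc2n1O`: > 100000 nM, a limit of the assay
- Compound 2 `O=C(O)c1cc2ccc(-c3ccc(Cl)cc3)cc2n1O`: > 100000 nM, a limit of the assay
- Compound 3 `O=C(O)c1cc2ccc(-c3ccc(Cl)cc3Cl)cc2n1O`: > 100000 nM, a limit of the assay

Compound 2 has no exact number in this assay. Its entry of > 100000 nM is a limit, not a measured value. The other two compounds offer no firmer reference point, as the whole set shows (the limit of > 100000 nM in this assay, at which 3 of the 3 values shown sit).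

Compound 4 `O=C(O)CCc1ccc(-c2ccc3cc(C(=O)O)n(O)c3c2)cc1` has 2-carboxyethyl in place of chloro on an aromatic carbon, para to a large group: 2-carboxyethyl in place of chloro on an aromatic carbon.

Among the measured compounds shown here, only one measured step starts from compound 2, and it concerns a different change, chloro in place of hydrogen on an aromatic carbon. This is a step that the two limits leave unreadable from compound 2 to compound 3, so it gives no size to carry over. With only the limit of > 100000 nM in this assay, at which 3 of the 3 values shown sit, to go on, no step beyond the usual scatter is expected, and no direction can be assigned. The expected step is a number no higher from compound 2 to compound 4 (the limit leaves the size open).

For compound 4 the estimate is 100000 nM, with an expected range of 50000 nM to 200000 nM.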

Compound 4, half-maximal inhibitory concentration: > 100000 nM
Compound 4 was reported as a limit; the forecaster's own chance of this, stated with the estimate: 85%; the middle value lies on the limit itself.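

No size can be read for the change from compound 2 to compound 4, because both entries are limits and not exact numbers: the limit of > 100000 nM in this assay, at which 4 of the 4 values shown sit.

The compounds shown leave open what exact value any of them would give in this assay, and so whether 2-carboxyethyl in place of chloro changes anything there.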